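The compounds below may be only part of what the source reports. "The series", "measured", "known", "first", "only" and "open" are said of these compounds alone.

Values in a functional assay on PC-3 cells (Homo sapiens) for cytotoxicity, read by MTT assay, with a stated time of 72 h; a lower number here means a stronger inhibitor, a higher number a weaker inhibitor:

Compound 1 `COc1ccc(/C=C/C(=O)Nc2cc3c(Nc4ccc(F)c(Cl)c4)ncnc3cc2OC)cc1`: "not active" (no number reported)
Compound 2 `COc1cc2ncnc(Nc3ccc(F)c(Cl)c3)c2cc1NC(=O)/C=C/c1ccccc1[N+](=O)[O-]`: 14300 nM
Compound 3 `COc1cc2ncnc(Nc3ccc(F)c(Cl)c3)c2cc1NC(=O)/C=C/c1ccc(C#N)cc1`: "not active" (no number reported)

Compound 3 has no single number to place on a scale. In this assay compound 3 is recorded as "not active" (no number reported), and compound 1 is recorded in the same way as "not active" (no number reported). Only compound 2 gives a figure, at 14300 nM, so this small set offers one numerical reference point.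

The next structure is compound 4 `COc1cc2ncnc(Nc3ccc(F)c(Cl)c3)c2cc1NC(=O)/C=C/c1cc(OC)c(OC)c(OC)c1`. The change is 3,4,5-trimethoxyphenyl in place of 4-cyanophenyl on a double-bonded chain carbon bound to a double-bonded chain carbon. In words, 3,4,5-trimethoxyphenyl stands in place of 4-cyanophenyl on a double-bonded chain carbon bound to a double-bonded chain carbon, while the rest of the molecule stays the same.

Among the compounds with values here, no measured pair shows what a single change of this kind does, so any forecast is rough. The most likely gain is a small one, from no reported number to a weak but measurable value in the same region as compound 2 at 14300 nM. A strong gain in potency is not expected, and another result without a number is quite possible.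

The estimate for compound 4 is 15000 nM, with an expected range of 6000 nM to 40000 nM.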

Compound 4, half-maximal inhibitory concentration: 38200 nM
The estimate for compound 4 lay 2.5-fold (0.41 log units) below the measured number; measured number inside the range.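

In this assay compound 3 is recorded as "not active" (no number reported) while compound 4 gives 38200 nM as a number, so with 3,4,5-trimethoxyphenyl in place of 4-cyanophenyl on a double-bonded chain carbon bound to a double-bonded chain carbon, a figure can be read where none existed, although the size of that change cannot be read. Within the data shown here, the one step that can be read, with 3,4,5-trimethoxyphenyl in place of 2-nitrophenyl at the same place, is a 2.7-fold higher number from compound 2 to compound 4 (0.43 log units; beyond the scatter) and shows a modest loss of potency, so this position now has two numbers to compare and the choice of aromatic group there moves the result measurably. No measurement shown here accounts for these differences between the groups.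

The compounds shown leave open how a plain unsubstituted phenyl, an amine or a carboxylic acid would read at this place, and whether any group there could reach much lower numbers. They also leave open which of the three methoxy groups of compound 4 matters, since the three are changed together as one group.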